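The source may report more compounds than this note shows. Statements on the series, on what has been measured and on what is new or still open speak of the compounds shown alone.

The series was examined in a functional assay on DU-145 cells (Homo sapiens) for inhibition, read by trypan blue exclusion, with a stated time of 96 h; a higher number here means a weaker inhibitor of growth, a lower number a stronger inhibitor of growth. Compound 2 `O=C(/C(=C\c1ccc(Oc2ccccc2)cc1)SCc1ccccc1Cl)c1ccc(Cl)cc1` gives 1000 nM in this assay. Compound 1 `Cc1ccc(S/C(=C/c2ccc(Oc3ccccc3)cc2)C(=O)c2ccc(Cl)cc2)cc1` differs from it in one place, (4-methylphenyl in place of 2-chlorobenzyl on a sulfur), and in this assay compound 1 gives 10000 nM; that change produced a 10-fold higher number from compound 2 to compound 1 (1.00 log units; beyond the scatter). Compound 3 `CCOc1ccc(/C=C(\C(=O)c2ccc(Cl)cc2)S(=O)(=O)Cc2ccccc2Cl)cc1OC` is built on another core, and the difference between the two cores is not broken down here. In this assay compound 3 gives 10000 nM, level with compound 1 at the digits recorded, the two together standing at the highest number of the three. Compound 4 `CCOc1ccc(/C=C(\C(=O)c2ccc(Cl)cc2)S(=O)(=O)c2ccc(C)cc2)cc1OC` has not yet been measured. It differs from compound 3 by 4-methylphenyl in place of 2-chlorobenzyl on a sulfonyl sulfur. This is the same kind of change as that from compound 2 to compound 1, but not the same one: in compound 3 the group sits on a sulfonyl sulfur whose other neighbours are a double-bonded chain carbon, whereas in compound 2 it sits on a sulfur whose other neighbours are a double-bonded chain carbon. Because the earlier change gave a 10-fold higher number from compound 2 to compound 1 (1.00 log units; beyond the scatter), compound 4 is expected to show a 3.0-fold higher number from compound 3 to compound 4 (0.48 log units; beyond the scatter). Compound 3 already stands at 10000 nM, the highest number measured in the series. Compound 4 is estimated at 30000 nM in this assay, expected to fall between 10000 nM and 100000 nM.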

Compound 4, concentration for 50% growth inhibition: 1000 nM
Beside the measured number, compound 4's estimate is 30-fold (1.48 log units) above it; measured number outside the range, below it.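

In this assay, putting 4-methylphenyl in place of 2-chlorobenzyl on a sulfonyl sulfur gave a 10-fold lower number from compound 3 to compound 4 (1.00 log units; beyond the scatter). Set beside the earlier step, the same exchange ran in opposite directions on the two cores: the same change on two cores in this assay, a 10-fold higher number (1.00 log units; beyond the scatter) from compound 2 to compound 1 and a 10-fold lower number (1.00 log units; beyond the scatter) from compound 3 to compound 4, 100-fold (2.00 log units) apart, beyond the scatter of two such steps. This shows that, across these four compounds, the step seen on one core cannot be carried over to the other, even in direction, but it does not show which part of the difference between the cores lies behind the reversal, and each core rests on a single pair of compounds.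

The compounds shown leave open whether the reversal extends to other groups on the sulfur, such as an unsubstituted benzyl or a longer phenylethyl chain. Also open, going by these compounds, is what the sulfonyl group alone contributes when the rest of the core is held fixed.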